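Swapping methyl for chloro on the phenyl of compound 3

The source may report more compounds than this note shows. Statements on the series, on what has been measured and on what is new or still open speak of the compounds shown alone.

Measured compounds:
compound 1 `CCOC(=O)c1c(-c2cc3ccccc3oc2=O)nn(-c2cccc(Cl)c2)c1C(=O)OCC` gives 35000 nM
compound 2 `CCOC(=O)c1c(-c2cc3cc(OC)ccc3oc2=O)nn(-c2ccccc2)c1C(=O)OCC` gives 27000 nM
compound 3 `CCOC(=O)c1c(-c2cc3cc(OC)ccc3oc2=O)nn(-c2cccc(C)c2)c1C(=O)OCC` gives 31000 nM

All three were tested in a functional assay on DU-145 cells (Homo sapiens) for cytotoxicity, read by MTT assay, with a stated time of 48 h; on this read-out lower numbers stand for stronger inhibition and higher numbers for weaker inhibition. Compound 3 stands second highest of the three numbers, with compound 1 nearest and compound 2 furthest, both within the scatter. The step from compound 2 to compound 3 was a 1.1-fold higher number from compound 2 to compound 3 (0.06 log units; within the scatter), so adding a methyl on the phenyl ring changed nothing beyond the scatter.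

Compound 4 `CCOC(=O)c1c(-c2cc3cc(OC)ccc3oc2=O)nn(-c2cccc(Cl)c2)c1C(=O)OCC` has not yet been measured in this assay. It differs from compound 3 by chloro in place of methyl on an aromatic carbon. Among the compounds with values here, the only measured step that bears on this position is the one from compound 2 to compound 3, and it was within the scatter. Compound 1, which carries the same chloro-bearing phenyl but lacks the methoxy, gives a number close to compound 3. Taken together, compound 4 is expected to show a 1.1-fold higher number from compound 3 to compound 4 (0.03 log units; within the scatter), with no movement beyond the scatter in either direction. The estimate for compound 4 in this assay is therefore 33000 nM, between 16000 nM and 68000 nM.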

Compound 4, half-maximal inhibitory concentration: 29000 nM
Compound 4: the middle estimate sits 1.1-fold (0.06 log units) above what was measured, and the stated range covers the measured number.
By their numbers in this assay, from the lowest: compounds 2, 4, 3 and 1 (each within the scatter of the next).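

In this assay, chloro in place of methyl on the phenyl gave a 1.1-fold lower number from compound 3 to compound 4 (0.03 log units; within the scatter) and chloro in place of hydrogen on the same aromatic carbon gave a 1.1-fold higher number from compound 2 to compound 4 (0.03 log units; within the scatter) so the three groups now read at this place, hydrogen, methyl and chloro, do not separate from one another. This extends the earlier single step on this ring, which compared only hydrogen with methyl, to a group that holds a chlorine instead of a carbon. With the 3-chlorophenyl held fixed, methoxy in place of hydrogen on the core gave a 1.2-fold lower number from compound 1 to compound 4 (0.08 log units; within the scatter) and so this second place also shows no step beyond the scatter in this pair.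

On these data alone, whether an amine, a carboxylic acid or a longer chain on this aromatic carbon would give a step beyond the scatter stays open. No measurement at hand explains why these numbers stay so close together.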